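Swapping an oxetane for an azetidine on a chemokine receptor antagonist

The compounds below may be only part of what the source reports. "The series", "measured", "known", "first", "only" and "open" are said of these compounds alone.

Compound 1 `COC1CCN(CC(=O)N2CCN(c3sc(C(F)(F)F)nc3-c3nc4ccccc4[nH]3)C[C@H]2C)C1` gives 3380 nM in a functional assay on Venous blood for antagonist activity at C-X-C chemokine receptor type 3 (Homo sapiens), read by flow cytometry, with a stated time of 30 min, in the presence of a further agent that is not named here; on this read-out higher numbers stand for weaker inhibition and lower numbers for stronger inhibition.
Compound 2 `Cc1nc(C)n(CC(=O)N2CCN(c3sc(C(F)(F)F)nc3-c3nc4ccc(OC5COC5)cc4[nH]3)C[C@H]2C)n1` gives 1480 nM in this assay.
Compound 3 `C[C@@H]1CN(c2sc(C(F)(F)F)nc2-c2nc3ccccc3[nH]2)CCN1C(=O)Cn1cnc2c1CCN(C)C2` gives 135 nM in this assay.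

Among the three measured compounds, compound 2 stands second highest in this assay: compound 1 lies above it, beyond the scatter, and compound 3 lies well below it. Going by the values given here, the only step in which two measured compounds differ in a single place, a 25-fold lower number from compound 1 to compound 3 (1.40 log units; beyond the scatter), concerns the group on the saturated chain carbon bound to the carbonyl carbon, at the other end of the shared core.

Compound 4 `Cc1nc(C)n(CC(=O)N2CCN(c3sc(C(F)(F)F)nc3-c3nc4ccc(OC5CNC5)cc4[nH]3)C[C@H]2C)n1` differs from compound 2 only at the oxygen on the aromatic ring: azetidin-3-yl in place of oxetan-3-yl on an oxygen on an aromatic ring. Among the compounds with values here, no measured step touches this position, and no measured pair differs only there. The expectation therefore rests on the small size of the change alone. A modest effect in this assay is expected, in either direction, most likely within or close to the scatter. Compound 4 is estimated at 1000 nM, with a range from 300 nM to 4000 nM. The step this estimate means, a 1.5-fold lower number from compound 2 to compound 4 (0.17 log units; within the scatter), is expected to be small.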

Compound 4, half-maximal inhibitory concentration: 580 nM
The estimate for compound 4 lay 1.7-fold (0.24 log units) above the measured number; the measured number falls inside the stated range.
By their numbers in this assay, from the lowest: compound 3; then compound 4; then compound 2; then compound 1.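

This is the only step shown at the group on the oxygen on the aromatic ring: in this assay, azetidin-3-yl in place of oxetan-3-yl gives a 2.6-fold lower number from compound 2 to compound 4 (0.41 log units; beyond the scatter). The position therefore responds to a small edit, since the two groups have the same number of heavy atoms and the same four-membered ring, differing in one ring atom, nitrogen for oxygen, and in the hydrogen-bond donor counted for azetidin-3-yl. There is no supporting measurement that explains the shift, so the data do not show whether the ring nitrogen, the added donor or something else accounts for it.

The compounds shown leave open how much the ring nitrogen can tolerate, for example with a methyl or an acetyl group placed on it, and whether a larger pyrrolidine or piperidine ring on the same oxygen would move the number further. They also leave open whether the same swap would give a similar step when the dimethyl-triazole end of compound 4 is replaced by the group carried at that end by compound 3.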